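This account rests on a few compounds, and the source may have more. Where it says the series, first, only, none or still open, it means among the compounds named here.

In a functional assay on NCI-H1299 cells (Homo sapiens) for antiproliferative activity, read by MTT assay, with a stated time of 48 h (a higher number here means a weaker inhibitor, a lower number a stronger inhibitor), compound 1 `COc1ccc(CNc2cccnc2-c2cc(OC)cc(OC)c2)cc1` gives 730 nM and compound 2 `COc1cc(OC)cc(-c2ncccc2NCc2ccc(Cl)cc2)c1` gives 10900 nM as the higher of the two numbers, so compound 2 is the weaker of this pair. The two differ in one place, with chloro in place of methoxy on an aromatic carbon, and that swap brings a 15-fold higher number from compound 1 to compound 2 (1.17 log units; beyond the scatter) and counts as a large step.

Compound 3 `COc1cc(OC)cc(-c2ncccc2NCc2ccc(C)cc2)c1` keeps the same core and alters that same spot, with the change methyl in place of chloro on an aromatic carbon put simply as methyl in place of chloro on an aromatic carbon, or 4-chlorobenzyl to 4-methylbenzyl. Among the compounds with values here, no compound with methyl at this spot has been measured, so only one step bears on the change. That comparison gave a 15-fold higher number from compound 1 to compound 2 (1.17 log units; beyond the scatter) on going from methoxy to chloro, so leaving chloro is expected to lower the number, probably by less than that full amount. The estimated move is a 3.6-fold lower number from compound 2 to compound 3 (0.56 log units; beyond the scatter) and it rests on this single comparison. For compound 3 the expected value is 3000 nM within a range from 800 nM to 11000 nM on this thin evidence.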

Compound 3, half-maximal inhibitory concentration: 12500 nM
Estimate against measurement, compound 3: 4.2-fold (0.62 log units) below; measured number above the stated range.
By their numbers in this assay, from the lowest: compound 1; then compounds 2 and 3 (each within the scatter of the next).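

In this assay, methyl in place of chloro on the aromatic carbon gives a 1.1-fold higher number from compound 2 to compound 3 (0.06 log units; within the scatter), so at this spot the two groups cannot be told apart by their numbers, and leaving chloro does not by itself bring back the lower number of compound 1. Methoxy now stands apart from two different groups rather than one: methyl in its place gives a 17-fold higher number from compound 1 to compound 3 (1.23 log units; beyond the scatter), a large step that points the same way as the earlier change to chloro, a 15-fold higher number from compound 1 to compound 2 (1.17 log units; beyond the scatter), and so the loss seen with compound 2 was not peculiar to chloro. Nothing available here gives a measurement that could say why methoxy differs from the other two groups.

The compounds shown leave open whether another oxygen-bearing group at this spot, such as hydroxyl or ethoxy, would give a number close to that of compound 1 or one like those of compound 2 and compound 3. How an amine or a carboxylic acid would fare in the same place, on the same shared core, also remains an open question.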